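The compounds below may be only part of what the source reports. "The series", "measured", "known", "first", "only" and "open" are said of these compounds alone.

Measured compounds in a functional assay on MKN-45 cells (Homo sapiens) for cytotoxicity, read by MTT assay, with a stated time of 72 h; a lower number here means a stronger inhibitor, a higher number a weaker inhibitor:

compound 1, `CN(C)CCn1cnnc1-c1cc(Oc2ccc(NC(=O)N/N=C/c3cccc(Br)c3)cc2F)ccn1`: 450 nM
compound 2, `CN(C)CCn1cnnc1-c1cc(Oc2ccc(NC(=O)N/N=C/c3cccc(O)c3)cc2F)ccn1`: 1370 nM
compound 3, `CN(C)CCn1cnnc1-c1cc(Oc2ccc(NC(=O)N/N=C/c3ccc(O)c(O)c3)cc2F)ccn1`: 3240 nM

Compound 2 stands second highest of these three numbers. Around it, the step of a 2.4-fold higher number from compound 2 to compound 3 (0.37 log units; beyond the scatter) is the smaller one, and the step of a 3.0-fold higher number from compound 1 to compound 2 (0.48 log units; beyond the scatter) the larger; both lie beyond the scatter, so compound 2 is set apart from each of its neighbours. The step of a 7.2-fold higher number from compound 1 to compound 3 (0.86 log units; beyond the scatter) spans the whole range seen so far.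

Compound 4, `CN(C)CCn1cnnc1-c1cc(Oc2ccc(NC(=O)N/N=C/c3cc(Br)c(O)c(Br)c3)cc2F)ccn1`, has not yet been measured. It differs from compound 2 in one place: 3,5-dibromo-4-hydroxyphenyl in place of 3-hydroxyphenyl on a carbon with a double bond to nitrogen. Among the compounds with values here, two measured steps bear on this change. Replacing bromo by hydroxy raised the number in the step from compound 1 to compound 2, so a phenyl that again carries bromine is expected to pull the number back down. The added hydroxy in the step from compound 2 to compound 3 raised the number, which argues against a large gain. On balance a modest lowering in this assay is expected, beyond the scatter but well short of compound 1. Compound 4 is therefore estimated at about 700 nM, within 250 nM to 2000 nM. This corresponds to an expected step of a 2.0-fold lower number from compound 2 to compound 4 (0.29 log units; within the scatter).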

Compound 4, half-maximal inhibitory concentration: 4320 nM
For compound 4 the middle estimate is 6.2-fold (0.79 log units) below the measured one, outside the stated range (above it).
By their numbers in this assay, from the lowest: compound 1; then compound 2; then compounds 3 and 4 (each within the scatter of the next).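

In this assay, the return of bromine to the phenyl ring did not lower the number: 3,5-dibromo-4-hydroxyphenyl in place of 3-hydroxyphenyl gave a 3.2-fold higher number from compound 2 to compound 4 (0.50 log units; beyond the scatter), and the distance from the 3-bromophenyl compound is a 9.6-fold higher number from compound 1 to compound 4 (0.98 log units; beyond the scatter). The new group instead reads level with 3,4-dihydroxyphenyl, with a 1.3-fold higher number from compound 3 to compound 4 (0.12 log units; within the scatter), so at this carbon with a double bond to nitrogen, bromine alone does not mark out the low number of compound 1, the only compound shown whose phenyl has no hydroxy group. Nothing available gives a reason for this result.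

On these data alone, whether the hydroxy group or the bromo groups set the number of compound 4 remains open. Also open, as far as these compounds go, is how a methoxy group or an amine in place of that hydroxy group would read.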